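A few compounds are considered here, and "the series" means these few. Any claim that something is new, unique, unknown or untested is made for them only; others in the source may bear on it.

Compound 1 `COc1cc(F)c(CN2C(=O)N(c3ccc(OC)c(OC)c3)S(=O)(=O)c3ccccc32)c(Cl)c1` is the stronger of the two compounds measured in an assay on HEK293 cells for displacement of a labelled ligand from Orexin receptor type 2 (Homo sapiens), read by scintillation counting, with a stated time of 90 min; a lower number here means a stronger inhibitor, a higher number a weaker inhibitor; there compound 1 gives 0.1 nM, and compound 2 `COc1cc(N2C(=O)N(Cc3c(F)cc(F)cc3F)c3ccccc3S2(=O)=O)ccn1` gives 63.1 nM, a gap beyond the usual scatter. Compound 3 `COc1ccc(N2C(=O)N(Cc3c(F)cc(F)cc3OC)c3ccccc3S2(=O)=O)cc1OC` has not yet been measured. It differs from compound 1 in one place: 2,4-difluoro-6-methoxyphenyl in place of 2-chloro-6-fluoro-4-methoxyphenyl on a saturated chain carbon bound to an amide-type nitrogen in a ring. Among the measured compounds shown here, no measured pair isolates this change, so its effect is open; a moderate loss is expected, so that the step of a 10-fold higher number from compound 1 to compound 3 (1.00 log units; beyond the scatter) is estimated to go beyond the scatter. Compound 3 is expected to give about 1 nM, within a range from 0.2 nM to 8 nM.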

Compound 3, inhibition constant: 6.31 nM
Estimate against measurement, compound 3: 6.3-fold (0.80 log units) below, within the range that was stated.
By their numbers in this assay, from the lowest: compound 1; then compound 3; then compound 2.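

The 2-chloro-6-fluoro-4-methoxybenzyl position proves sensitive in this assay: replacing this group with 2,4-difluoro-6-methoxybenzyl gives a 63-fold higher number from compound 1 to compound 3 (1.80 log units; beyond the scatter), a large step, although both groups hold the same count of heavy atoms. Nothing measured here accounts for the size of this step. Going by these compounds, whether the loss of chlorine or the new placing of the methoxy group carries the step remains open. So does how an amine or a carboxylic acid on this benzyl group would read in this assay.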